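A few compounds are considered here, and "the series" means these few. Any claim that something is new, unique, unknown or untested is made for them only; others in the source may bear on it.

For the measured compounds named here, in a functional assay on HT cells (Homo sapiens) for antiproliferative activity, read by fluorescence, with a stated time of 72 h (on this read-out lower numbers stand for stronger inhibition of growth and higher numbers for weaker inhibition of growth), compound 1 (`CC(O)CSc1nc(NCc2ccc(-c3ccccn3)cc2)c2[nH]nc(C(C)C)c2n1`) gives 62 nM and compound 2 (`CC(C)c1n[nH]c2c(NCc3ccc(-c4ccccn4)cc3)nc(SCCNC(=N)N)nc12`) gives 390 nM, the higher of the two numbers so far. Compound 3 (`CC(C)c1n[nH]c2c(NCc3ccc(-c4ccccn4)cc3)nc(SC3CCCC3O)nc12`) differs from compound 2 by a group of 6 heavy atoms (5 carbon, 1 oxygen; one five-membered non-aromatic ring of carbon only) in place of a group of 6 heavy atoms (3 carbon, 3 nitrogen; no ring), on a sulfur and so carries a 2-hydroxycyclopentyl on the sulfur. Going by the values given here, one measured step bears on this: a 6.3-fold higher number from compound 1 to compound 2 (0.80 log units; beyond the scatter) as the oxygen-bearing group of compound 1 gave way to the group of compound 2. On these data alone, compound 3 regains an oxygen-bearing group, though its ring remains untested, so the expected change is a 4.3-fold lower number from compound 2 to compound 3 (0.64 log units; beyond the scatter) in this assay and runs toward stronger inhibition. Compound 3 is therefore estimated at 90 nM (range 30 nM to 270 nM).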

Compound 3, concentration for 50% growth inhibition: 567 nM
The estimate for compound 3 lay 6.3-fold (0.80 log units) below the measured number; the measured number lies above the stated range.
By their numbers in this assay, from the lowest: compound 1; then compounds 2 and 3 (each within the scatter of the next).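

In this assay, the step of a 9.1-fold higher number from compound 1 to compound 3 (0.96 log units; beyond the scatter) shows that keeping an oxygen-bearing group on the sulfur does not preserve the lower number when 2-hydroxycyclopentyl replaces 2-hydroxypropyl. The step of a 1.5-fold higher number from compound 2 to compound 3 (0.16 log units; within the scatter) places the 2-hydroxycyclopentyl group level with the ring-free group of compound 2, so the hydroxyl alone does not bring the number of compound 1 at this position.

On these data alone, whether a plain cyclopentyl, a longer hydroxyalkyl chain or a carboxylic acid on this sulfur would match compound 1 remains open. Nothing available accounts for the gap between the two hydroxyl-bearing groups.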